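Compound 3 to compound 4: one more fluoro

This account rests on a few compounds, and the source may have more. Where it says the series, first, only, none or still open, it means among the compounds named here.

Compound 1 (`CC(C)[C@H](NC(=O)COc1cccc2ccccc12)C(=O)N[C@@H](CC(=O)O)C(=O)COc1cccc2ccccc12`) gives > 100000 nM in a functional assay on Jurkat cells (Homo sapiens) (a lower number here means a stronger inhibitor, a higher number a weaker inhibitor), which is a limit and not a number. Compound 2 (`CC(C)[C@H](NC(=O)COc1cccc2ccccc12)C(=O)N[C@@H](CC(=O)O)C(=O)COc1cccc(C(F)(F)F)c1`) gives > 100000 nM in this assay, again a limit. Compound 3 (`CC(C)[C@H](NC(=O)COc1cccc2ccccc12)C(=O)N[C@@H](CC(=O)O)C(=O)COc1ccc(F)c(F)c1`) gives > 100000 nM in this assay, also only a limit. The series therefore offers one piece of evidence: the limit of > 100000 nM in this assay, at which 3 of the 3 values shown sit.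

The change to compound 4 (`CC(C)[C@H](NC(=O)COc1cccc2ccccc12)C(=O)N[C@@H](CC(=O)O)C(=O)COc1cc(F)c(F)cc1F`) is fluoro in place of hydrogen on an aromatic carbon, so that 3,4-difluorophenyl becomes 2,4,5-trifluorophenyl.

The measured steps that bear on this are the exchanges of the group on the same oxygen: a step that the two limits leave unreadable from compound 1 to compound 2, a step that the two limits leave unreadable from compound 1 to compound 3 and a step that the two limits leave unreadable from compound 2 to compound 3. None of them has a readable size, so no step beyond the scatter and no direction can be founded on them in this assay. The expected step is a number no higher from compound 3 to compound 4 (the limit leaves the size open), with no shift anticipated. Compound 4 is estimated at 100000 nM, with an expected range from 30000 nM to 300000 nM, and a further limit is the likeliest report.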

Compound 4, half-maximal inhibitory concentration: 39300 nM
Estimate against measurement, compound 4: 2.5-fold (0.41 log units) above; measured number inside the range.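

Going by these compounds alone, the fluoro on the aromatic carbon ortho to a large group gives an at least 2.5-fold lower number from compound 3 to compound 4 (0.40 log units; beyond the scatter) in this assay, the first step with a readable direction. Among the groups on the same oxygen, 2,4,5-trifluorophenyl also gives an at least 2.5-fold lower number from compound 2 to compound 4 (0.40 log units; beyond the scatter) and an at least 2.5-fold lower number from compound 1 to compound 4 (0.40 log units; beyond the scatter), so compound 4 is the only compound shown with a measured number. The steps among compound 1, compound 2 and compound 3 cannot be read, and those three compounds share a single limit: the limit of > 100000 nM in this assay, at which 3 of the 4 values shown sit.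

From the compounds shown here alone, each of the new steps gives only a minimum size, and the full size remains unknown. Also open, going by these compounds, is whether chloro or methoxy on the same aromatic carbon would give a lower number than fluoro, and whether this fluoro would give a step on a phenyl ring carrying no other fluoro.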